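From morpholin-4-yl to dimethylamino: compound 1 and compound 4

The source may report more compounds than this note shows. Statements on the series, on what has been measured and on what is new or still open speak of the compounds shown alone.

In an in vitro ADME assay on microsomes from liver (Rattus norvegicus) for metabolic stability (a higher number here means faster removal of the compound, a lower number slower removal), compound 1 (`CC[C@H](C)[C@@H]1C(=O)N[C@H](C2Cc3ccccc3C2)C(=O)N1[C@@H](C(=O)N1CCOCC1)c1cnc(C)cc1C`) gives 1 mL.min-1.g-1. Compound 2 (`CCC(CC)[C@@H]1C(=O)N[C@H](C2Cc3ccccc3C2)C(=O)N1[C@@H](C(=O)N1CCOCC1)c1ccc(C)nc1`) gives 1 mL.min-1.g-1, level with compound 1, and compound 3 (`CCC(CC)[C@@H]1C(=O)N[C@H](C2Cc3ccccc3C2)C(=O)N1[C@@H](C(=O)NC)c1ccc(C)nc1C`) gives 2 mL.min-1.g-1, within the scatter of both. Compound 4 (`CC[C@H](C)[C@@H]1C(=O)N[C@H](C2Cc3ccccc3C2)C(=O)N1[C@@H](C(=O)N(C)C)c1cnc(C)cc1C`) carries dimethylamino in place of morpholin-4-yl on a carbonyl carbon. Among the measured compounds shown here, no measured pair isolates this change. Compound 3 has another group on that carbonyl and differs elsewhere as well, yet its 2 mL.min-1.g-1 stays within the scatter of compound 1. No step beyond the scatter is therefore expected in this assay, and the expected step is a 1.5-fold higher number from compound 1 to compound 4 (0.18 log units; within the scatter). Compound 4 is estimated at 1.5 mL.min-1.g-1, with an expected range of 0.7 mL.min-1.g-1 to 4 mL.min-1.g-1.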

Compound 4, intrinsic clearance in microsomes: 1 mL.min-1.g-1
Compound 4: middle estimate off by 1.5-fold (0.18 log units), on the high side; the measured number falls inside the stated range.
By their numbers in this assay, from the lowest: compounds 1, 2, 4 and 3 (each within the scatter of the next).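

Dimethylamino in place of morpholin-4-yl on a carbonyl carbon gives no change at the digits printed from compound 1 to compound 4 (within the scatter) in this assay and is the only step here that isolates this position. On the core of compound 1, the six-membered ring and its oxygen are therefore not needed to keep the number at this level. Nothing measured accounts for this result. As far as these compounds go, what a piperazine or a carboxylic acid on this carbonyl carbon would give remains open. So does whether the same exchange reads alike on the core of compound 2.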